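The compounds below may be only part of what the source reports. "The series", "measured", "known", "first", "only" and "open" are said of these compounds alone.

Compound 2 `O=C(OC1CCC(CN2CCN(c3cc(=O)c4cc(C(F)(F)F)cc([N+](=O)[O-])c4s3)CC2)CC1)c1ccncc1` was tested in an ADME assay on Vero cells (Chlorocebus sabaeus) for cytotoxicity, read by MTT assay, with a stated time of 48 h; a lower number here means a stronger inhibitor, a higher number a weaker inhibitor. In this assay compound 2 gives > 64 ug/mL, which is a limit of the assay rather than a number. For the measured compounds named here, its only measured neighbour is compound 1 `O=C(OC1CCC(CN2CCN(c3cc(=O)c4cc(C(F)(F)F)cc([N+](=O)[O-])c4s3)CC2)CC1)C1CCC1`. In this assay compound 1 likewise gives > 64 ug/mL, again a limit. Going by the values given here, the one step between the two, a step that the two limits leave unreadable from compound 1 to compound 2, cannot be read, since the limit of > 64 ug/mL in this assay, at which 2 of the 2 values shown sit, shows that both values sit at that limit. Compound 3 `O=c1cc(N2CCN(CC3CCC(OS(=O)(=O)c4ccc5c(c4)CCO5)CC3)CC2)sc2c([N+](=O)[O-])cc(C(F)(F)F)cc12` is the next compound to be measured. It differs from compound 2 in one place: a group of 12 heavy atoms (8 carbon, 3 oxygen, 1 sulfur; one five-membered non-aromatic ring with 1 hetero atom, one six-membered aromatic ring of carbon only) in place of a group of 8 heavy atoms (6 carbon, 1 nitrogen, 1 oxygen; one six-membered aromatic ring with 1 hetero atom), on an oxygen on a saturated carbon. Among the compounds with values here, the single measured step offers no readable size, so no step beyond the scatter can be foreseen in either direction. Compound 3 is therefore expected to sit near 64 ug/mL, within 30 ug/mL to 100 ug/mL, and most likely to be reported only as a limit again. The step this implies, a number no higher from compound 2 to compound 3 (the limit leaves the size open), is expected to be small.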

Compound 3, half-maximal inhibitory concentration: > 64 ug/mL
Compound 3: only a limit was reported; the forecaster's own chance of this, stated with the estimate: 75%; the middle value lies on the limit itself.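

No step among compound 1, compound 2 and compound 3 in this assay can be read, for a single reason: the limit of > 64 ug/mL in this assay, at which 3 of the 3 values shown sit. The compounds shown leave open at what concentration any of the three would harm these cells, and whether changing the group on the oxygen alters that concentration.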